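Dithiocarbamate chromone series: removing the methoxy

The source may hold more compounds than are shown below. What is called first, only, known or untested is meant among the compounds shown, and "the series" means these compounds.

Measured so far:
compound 1, `Cc1ccc2c(=O)c(CSC(=S)N3CCCCC3)coc2c1`, 1700 nM
compound 2, `COc1ccc2occ(CSC(=S)N3CCCCC3)c(=O)c2c1`, 930 nM

Two compounds share the same core and side chain and differ only in the substituent on the carbocyclic ring. In a functional assay on MDA-MB-435S cells (Homo sapiens) for antiproliferative activity, read by MTT assay, with a stated time of 72 h (on this read-out lower numbers stand for stronger inhibition and higher numbers for weaker inhibition), compound 2 gives 930 nM, the lower of the two numbers; compound 1 gives 1700 nM, and that gap lies within the scatter of repeated measurements, so the two read as equivalent on this assay.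

Compound 3, `O=c1c(CSC(=S)N2CCCCC2)coc2ccccc12`, is the unsubstituted parent and has not yet been measured. Relative to compound 2 the change is hydrogen in place of methoxy on an aromatic carbon. No step between measured compounds is available for this change, and the methyl-to-methoxy comparison between compound 1 and compound 2 shows no difference beyond the scatter, which gives no reason to expect a large effect here either.

The expectation for compound 3 is therefore a number close to that of compound 2, with a slight drift toward weaker inhibition at most, a step of a 1.4-fold higher number from compound 2 to compound 3 (0.15 log units; within the scatter). Compound 3 is estimated at 1300 nM, with a plausible range of 500 nM to 3500 nM.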

Compound 3, half-maximal inhibitory concentration: 470 nM
For compound 3 the middle estimate is 2.8-fold (0.44 log units) above the measured one; measured number below the stated range.
By their numbers in this assay, from the lowest: compounds 3, 2 and 1 (each within the scatter of the next, the first and the last beyond it).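

In this assay the methoxy of compound 2 gives way to hydrogen with a 2.0-fold lower number from compound 2 to compound 3 (0.30 log units; within the scatter) as the step, so compound 2 and compound 3 read as equivalent and this methoxy is not needed to hold activity at this level. Hydrogen in place of methyl is the only step so far that clears the scatter, modest in size, with a 3.6-fold lower number from compound 1 to compound 3 (0.56 log units; beyond the scatter) in this assay as its reading, so the methyl of compound 1 is the one substituent shown that separates from the unsubstituted compound 3. No independent measurement bears on the cause of either step.

Open, on these data alone, is whether any group on this aromatic carbon can move the number beyond the scatter in either direction, since only methoxy and hydrogen have been compared there. A chlorine atom, an amine or a carboxylic acid at the same place would test this, and would show whether the flat response between compound 2 and compound 3 extends beyond these two cases.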